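Trading methoxy for phenyl on an aromatic carbon

This account rests on a few compounds, and the source may have more. Where it says the series, first, only, none or still open, it means among the compounds named here.

In a functional assay on HCT-116 cells (Homo sapiens) for antiproliferative activity, read by WST assay, with a stated time of 72 h (on this read-out lower numbers stand for stronger inhibition of growth and higher numbers for weaker inhibition of growth), compound 1 (`O=C(NO)c1cnc(N2C[C@@H]3[C@H](C2)[C@H]3NCc2ccc(F)cc2)nc1`) gives 380 nM, compound 2 (`O=C(NO)c1cnc(N2C[C@@H]3[C@H](C2)[C@H]3NCc2ccc(OC(F)(F)F)cc2)nc1`) gives 120 nM and compound 3 (`COc1ccc(CN[C@H]2[C@@H]3CN(c4ncc(C(=O)NO)cn4)C[C@@H]32)cc1`) gives 190 nM. Compound 3 stands within the scatter of both others, as a 2.0-fold lower number from compound 1 to compound 3 (0.30 log units; within the scatter) and a 1.6-fold higher number from compound 2 to compound 3 (0.20 log units; within the scatter) show. Within the data shown here, only one measured step exceeds the scatter, namely a 3.2-fold lower number from compound 1 to compound 2 (0.50 log units; beyond the scatter), and it is modest. Compound 4 (`O=C(NO)c1cnc(N2C[C@@H]3[C@H](C2)[C@H]3NCc2ccc(-c3ccccc3)cc2)nc1`) carries a new change, (phenyl in place of methoxy on an aromatic carbon), with phenyl in place of methoxy on an aromatic carbon. Among the measured compounds shown here, no measured step brought in a ring, so these steps guide only loosely. The estimated step is a 1.3-fold lower number from compound 3 to compound 4 (0.10 log units; within the scatter), so no change beyond the scatter is expected in this assay. For compound 4 the estimate is 150 nM, with an expected range from 50 nM to 450 nM.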

Compound 4, concentration for 50% growth inhibition: 56 nM
Estimate against measurement, compound 4: 2.7-fold (0.43 log units) above; the measured number falls inside the stated range.
By their numbers in this assay, from the lowest: compound 4; then compounds 2, 3 and 1 (each within the scatter of the next, the first and the last beyond it).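

In this assay, phenyl on this aromatic carbon gives a lower number than methoxy (a 3.4-fold lower number from compound 3 to compound 4 (0.53 log units; beyond the scatter)), trifluoromethoxy (a 2.1-fold lower number from compound 2 to compound 4 (0.33 log units; beyond the scatter)) and fluoro (a 6.8-fold lower number from compound 1 to compound 4 (0.83 log units; beyond the scatter)). The earlier groups carried no ring, so compound 4 shows that this position accepts a whole aromatic ring and that the ring makes compound 4 the most potent of the four. Nothing measured here explains this gain. On these data alone, it remains open whether the gain needs an aromatic ring, which a cyclohexyl ring or a pyridine ring in the same place could test. A butyl chain could show whether size alone is enough.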